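Capping the phenol oxygen of compound 2 with a vinyl group

The compounds below may be only part of what the source reports. "The series", "measured", "known", "first", "only" and "open" are said of these compounds alone.

Compound 2 `COc1ccc(Cn2c(-c3ccccc3O)c(Br)c3ccccc3c2=O)cc1` is the starting point. Among the compounds with values here, in a functional assay on HL-60 cells (Homo sapiens) for cytotoxicity, read by sulforhodamine B assay (on this read-out lower numbers stand for stronger inhibition and higher numbers for weaker inhibition), compound 2 gives 31600 nM, the highest of the three numbers measured so far. Within the data shown here, its nearest neighbour is compound 3 `COc1ccc(Cn2c(-c3ccccc3O)c(Br)c3cc(C)ccc3c2=O)cc1`, which gives 24500 nM in this assay; the only single-point step available, a 1.3-fold lower number from compound 2 to compound 3 (0.11 log units; within the scatter), changes nothing that can be trusted. Furthest away lies compound 1 `COc1ccc(Cn2c3c(c4ccccc4c2=O)CCOc2ccccc2-3)cc1`, which gives 4490 nM, a lower number beyond the scatter, but it differs from compound 2 in more than one place.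

Compound 4 `C=COc1ccccc1-c1c(Br)c2ccccc2c(=O)n1Cc1ccc(OC)cc1` differs from compound 2 by vinyl in place of hydrogen on an oxygen on an aromatic ring. Among the measured compounds shown here, no measured step touches this oxygen: the one step known, from compound 2 to compound 3, sits on an aromatic carbon and stays within the scatter. With nothing pointing either way, no step beyond the scatter is expected for compound 4. The estimate for compound 4 in this assay is therefore 31600 nM, between 10000 nM and 100000 nM, an expected step of no change at the digits printed from compound 2 to compound 4 (within the scatter).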

Compound 4, half-maximal inhibitory concentration: 59500 nM
Compound 4: middle estimate off by 1.9-fold (0.27 log units), on the low side; low and high end bracket the measured number.
By their numbers in this assay, from the lowest: compound 1; then compounds 3, 2 and 4 (each within the scatter of the next, the first and the last beyond it).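

Vinyl in place of hydrogen on the oxygen on the aromatic ring gives, in this assay, a 1.9-fold higher number from compound 2 to compound 4 (0.27 log units; within the scatter) and so leaves the two compounds indistinguishable on this read-out. Within the data shown here, this is the first reading at this oxygen, since the earlier single-point step sat on an aromatic carbon, and it shows that the hydrogen here can be exchanged for vinyl without a step beyond the scatter. Nothing available bears on why this exchange behaves as it does.

With vinyl as the only replacement shown, no trend at this oxygen can be drawn. Going by these compounds, whether a methyl, a longer chain ending in an amine or a carboxylic acid on the same oxygen would give a step beyond the scatter remains open.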